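The source may report more compounds than this note shows. Statements on the series, on what has been measured and on what is new or still open speak of the compounds shown alone.

Going by the values given here, compound 1, `CC(C)[C@@H]1CC[C@@H](C)C[C@@]12N(C)C(=O)[C@@H]1[C@H]3C(=O)N(C)C(=O)[C@H]3ON12`, is the first of two compounds measured so far. In a functional assay, read by spectrophotometry, with a stated time of 2 h, tested at 2 mg/mL (a lower number here means a weaker effect, a higher number a stronger effect of the compound at the concentration tested), compound 1 gives 49.7%. Compound 2, `CC(C)[C@@H]1CC[C@@H](C)C[C@@]12N(C)C(=O)[C@@H]1[C@H]3C(=O)N(c4ccc(Cl)cc4)C(=O)[C@H]3ON12`, carries a 4-chlorophenyl in place of methyl on an amide-type nitrogen in a ring, and in this assay compound 2 gives 56.4%. The step of a number 6.7 percentage points higher from compound 1 to compound 2 (within the scatter) lies within the usual scatter, so the two numbers cannot be told apart and compound 2 simply stands beside compound 1.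

Compound 3, `COc1ccc(N2C(=O)[C@H]3[C@H](ON4[C@@H]3C(=O)N(C)[C@@]43C[C@H](C)CC[C@H]3C(C)C)C2=O)cc1`, differs from compound 2 by methoxy in place of chloro on an aromatic carbon. Among the compounds with values here, no measured step changes a group on this aromatic ring; the only step measured, a number 6.7 percentage points higher from compound 1 to compound 2 (within the scatter), exchanged the whole group on the ring nitrogen and moved the number within the scatter. On that basis little change is expected in this assay, a step of a number 1.4 percentage points lower from compound 2 to compound 3 (within the scatter) that should stay within the scatter. Compound 3 is therefore estimated at 55%, with a range from 42% to 68%.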

Compound 3, a percentage reported as activity, at one concentration (the size of the read-out at that concentration, not a potency): 55.7%
Estimate against measurement, compound 3: 0.7 percentage points below; the measured number falls inside the stated range.
By their numbers in this assay, from the lowest: compounds 1, 3 and 2 (each within the scatter of the next).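

Unlike the earlier pair, this result tests a change on the aromatic ring itself: methoxy in place of chloro, para to a large group, gives a number 0.7 percentage points lower from compound 2 to compound 3 (within the scatter) in this assay, so this exchange cannot be told apart from no change. The other step, 4-methoxyphenyl in place of methyl on the ring nitrogen, gives a number 6 percentage points higher from compound 1 to compound 3 (within the scatter), so a second aromatic group on that nitrogen also stays level with methyl. No outside measurement is available to explain why these numbers stay so close.

Open, going by these compounds, is whether a group of another kind at this ring position, such as an amine or a carboxylic acid, would move the number beyond the scatter. Also open, on these data alone, is whether a longer chain on the ring nitrogen would do so.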